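Benzothiazolyl acylthioureas: phenyl to thiophenyl swap, second pairing

The source may report more compounds than this note shows. Statements on the series, on what has been measured and on what is new or still open speak of the compounds shown alone.

Compound 1 `Nc1ccc2sc(NC(=S)NC(=O)c3ccccc3)nc2c1` gives 38600 nM in a functional assay on MCF7 cells (Homo sapiens) for cytotoxicity, read by MTT assay, with a stated time of 24 h; on this read-out higher numbers stand for weaker inhibition and lower numbers for stronger inhibition. Compound 2 `Nc1ccc2sc(NC(=S)NC(=O)c3cccs3)nc2c1` carries the change thiophen-2-yl in place of phenyl on a carbonyl carbon and gives 28400 nM in this assay, a step of a 1.4-fold lower number from compound 1 to compound 2 (0.13 log units; within the scatter). Compound 3 `O=C(NC(=S)Nc1nc2cc([N+](=O)[O-])ccc2s1)c1ccccc1` differs from compound 1 in the core by nitro in place of amino on an aromatic carbon; in this assay compound 3 gives 41600 nM, with a 1.1-fold higher number from compound 1 to compound 3 (0.03 log units; within the scatter). Compound 4 `O=C(NC(=S)Nc1nc2cc([N+](=O)[O-])ccc2s1)c1cccs1` is not yet measured; it differs from compound 3 by thiophen-2-yl in place of phenyl on a carbonyl carbon, the same change as from compound 1 to compound 2, at a place described in the same words. The step from compound 3 to compound 4 in this assay is expected to be a 1.4-fold lower number from compound 3 to compound 4 (0.14 log units; within the scatter), resting on the earlier 1.4-fold lower number from compound 1 to compound 2 (0.13 log units; within the scatter). Compound 4 is thus estimated at 30000 nM, between 15000 nM and 60000 nM.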

Compound 4, half-maximal inhibitory concentration: 35900 nM
Compound 4: middle estimate off by 1.2-fold (0.08 log units), on the low side, and the stated range covers the measured number.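

In this assay, thiophen-2-yl in place of phenyl on the core of compound 3 gives a 1.2-fold lower number from compound 3 to compound 4 (0.06 log units; within the scatter), and the two readings of this change agree: the same change on two cores in this assay, a 1.4-fold lower number (0.13 log units; within the scatter) from compound 1 to compound 2 and a 1.2-fold lower number (0.06 log units; within the scatter) from compound 3 to compound 4, 1.2-fold (0.07 log units) apart, within the scatter of two such steps. Nitro in place of amino, read with thiophen-2-yl on the carbonyl carbon, gives a 1.3-fold higher number from compound 2 to compound 4 (0.10 log units; within the scatter), and this change also reads alike in both settings: the same change on two cores in this assay, a 1.1-fold higher number (0.03 log units; within the scatter) from compound 1 to compound 3 and a 1.3-fold higher number (0.10 log units; within the scatter) from compound 2 to compound 4, 1.2-fold (0.07 log units) apart, within the scatter of two such steps. Among these compounds, every step here lies within the scatter, so the agreement shows only that neither change has a detectable effect on either core; it does not show that a change of real size would carry from one core to another.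

Still open, on these data alone, is whether a longer chain in place of phenyl on the carbonyl carbon, or a carboxylic acid in place of nitro on the aromatic carbon, would move the number beyond the scatter. Any such step would then need reading on both cores.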